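Swapping the thiazole for a chlorothiophene

The source may hold more compounds than are shown below. What is called first, only, known or untested is meant among the compounds shown, and "the series" means these compounds.

Compound 2: `CSc1cccc(Nc2nc(-c3nccs3)cs2)c1`, 9500 nM
Compound 1: `CSc1cccc(Nc2nc(-c3cccs3)cs2)c1`, "not active" (no number reported)

Both compounds share the same core and differ only in the five-membered ring that hangs from it. Among the compounds with values here, in an assay on CFBE41o cells for positive allosteric modulation of Cystic fibrosis transmembrane conductance regulator variant F508del (Homo sapiens), with stated times of 30 min and 24 h (a lower number here means that less compound is needed, a higher number that more compound is needed for the effect), compound 2 gives 9500 nM, and this is the only number in the set; compound 1 was reported as "not active" (no number reported) in this assay, so no value is available for it and nothing can be said about the size of any step between the two.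

Compound 3 is `CSc1cccc(Nc2nc(-c3cc(Cl)cs3)cs2)c1`. Compared with compound 2 the change is 4-chlorothiophen-2-yl in place of 1,3-thiazol-2-yl on an aromatic carbon. Since the closest measured relative that also carries a thiophene ring, compound 1, returned no number, the step from compound 2 to compound 3 is expected to go toward a higher number, so that more of compound 3 is needed, but with a wide uncertainty that includes no change beyond the scatter. The expected step is a 1.6-fold higher number from compound 2 to compound 3 (0.20 log units; within the scatter). For compound 3 the estimated value is 15000 nM, within a range from 5000 nM to 50000 nM, and there is a real chance that the assay reports no number at all.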

Compound 3, half-maximal effective concentration: 15000 nM
The estimate for compound 3 equals the measured number at the digits printed; the range from low to high includes it.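

With the chlorine on the thiophene ring, this assay gives a readable result: compound 3 has a value (15000 nM), whereas compound 1, which has the same ring without the chlorine, is reported as ("not active" (no number reported)). So a thiophene ring at this position, on an aromatic carbon next to the ring nitrogen, does not rule out a measurable effect, and the thiazole nitrogen of compound 2 is not needed for one. The replacement of 1,3-thiazol-2-yl by 4-chlorothiophen-2-yl gives a step (a 1.6-fold higher number from compound 2 to compound 3 (0.20 log units; within the scatter)) that leaves the two compounds indistinguishable in this measurement, and nothing available here explains why the chlorine separates compound 3 from compound 1.

On these data alone, it remains open whether this result is specific to chlorine or would also hold for a bromine, a methyl group or an amine on the thiophene ring. As far as these compounds go, it is equally open what a chlorine would do on the thiazole ring of compound 2, or what a carboxylic acid would do at this position.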